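Notes on the step from compound 3 to compound 4

The source may report more compounds than this note shows. Statements on the series, on what has been measured and on what is new or still open speak of the compounds shown alone.

Values in a functional assay on HCT-116 cells (Homo sapiens) for cytotoxicity, read by MTT assay, with a stated time of 72 h; on this read-out lower numbers stand for stronger inhibition and higher numbers for weaker inhibition:
compound 1 `O=C1c2c[n+]([O-])c3ccccc3c2C(=O)c2c1c1ccccc1n2Cc1cn(C[C@H](O)CO)nn1`: 400 nM
compound 2 `O=C1c2c[n+]([O-])c3ccccc3c2C(=O)c2c1c1ccccc1n2CCCCN1CCCCC1`: 200 nM
compound 3 `CN(C)CCCCn1c2c(c3ccccc31)C(=O)c1c[n+]([O-])c3ccccc3c1C2=O`: 450 nM

Two steps place compound 3: one within the scatter (a 1.1-fold higher number from compound 1 to compound 3 (0.05 log units; within the scatter)) and one beyond it (a 2.3-fold higher number from compound 2 to compound 3 (0.35 log units; beyond the scatter)).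

The change to compound 4 `O=C1c2c[n+]([O-])c3ccccc3c2C(=O)c2c1c1ccccc1n2CCCN1CCC(O)CC1` puts 4-hydroxypiperidin-1-yl in place of (dimethylamino)methyl on a saturated chain carbon, three bonds along the chain from an aromatic nitrogen. The closest measured comparison is the modest step between dimethylamino and piperidin-1-yl (a 2.3-fold higher number from compound 2 to compound 3 (0.35 log units; beyond the scatter)), here read in reverse. The step between the triazole-bearing compound and the piperidine (a 2.0-fold lower number from compound 1 to compound 2 (0.30 log units; within the scatter)) shows that very different chains can stay within the scatter. For the measured compounds named here, no measured compound carries 3-(4-hydroxypiperidin-1-yl)propyl, so the guide is only partial. A small move towards a lower number in this assay is expected, probably not beyond the scatter. The expected step is small (a 1.5-fold lower number from compound 3 to compound 4 (0.18 log units; within the scatter)). The estimate for compound 4 is 300 nM (expected range 130 nM to 700 nM).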

Compound 4, half-maximal inhibitory concentration: 190 nM
For compound 4 the middle estimate is 1.6-fold (0.20 log units) above the measured one, and the stated range covers the measured number.
By their numbers in this assay, from the lowest: compounds 4, 2, 1 and 3 (each within the scatter of the next, the first and the last beyond it).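

In this assay the 3-(4-hydroxypiperidin-1-yl)propyl chain of compound 4 gives a modest step beyond the scatter from the 4-(dimethylamino)butyl chain (a 2.4-fold lower number from compound 3 to compound 4 (0.37 log units; beyond the scatter)) and from the triazole-bearing chain (a 2.1-fold lower number from compound 1 to compound 4 (0.32 log units; beyond the scatter)). Against the piperidine chain the step stays within the scatter (a 1.1-fold lower number from compound 2 to compound 4 (0.02 log units; within the scatter)), so the shorter chain with its hydroxylated ring cannot be told apart from the longer chain with the plain ring. No measurement bears on the reason for these steps.

Compound 4 differs from compound 2 in both chain length and ring, leaving the contribution of each unresolved. The 3-(piperidin-1-yl)propyl and 4-(4-hydroxypiperidin-1-yl)butyl chains would each change only one of these, and a morpholine ring on the same chain would test a different ring atom in place of the hydroxyl-bearing carbon.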